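The source may hold more compounds than are shown below. What is called first, only, known or untested is meant among the compounds shown, and "the series" means these compounds.

Four close relatives are compared here, all built on one shared core. Compound 1 `CCCCCCCCNC(=O)[C@@H](NC(=O)/C=C/c1ccccc1)[C@@H](C)O` is the reference. In a functional assay on HepG2 cells (Homo sapiens) for cytotoxicity, read by MTT assay, with a stated time of 48 h (on this read-out higher numbers stand for weaker inhibition and lower numbers for stronger inhibition), compound 1 gives 55600 nM. Compound 2 `C/C=C/C=C/C(=O)N[C@H](C(=O)NCCCCCCCC)[C@@H](C)O` differs from it in a single spot, (prop-1-en-1-yl in place of phenyl on a double-bonded chain carbon bound to a double-bonded chain carbon), and in this assay compound 2 gives 102000 nM; that change gave a 1.8-fold higher number from compound 1 to compound 2 (0.26 log units; within the scatter). Compound 3 `CCCCCCCCCCCCCCCCCCNC(=O)[C@@H](NC(=O)/C=C/c1ccccc1)[C@@H](C)O` keeps the phenyl end and instead differs from compound 1 in the chain, (decyl in place of hydrogen on a saturated chain carbon, eight bonds along the chain from an amide-type nitrogen). In this assay compound 3 gives 128000 nM, the highest of the three numbers, and the chain change gave a 2.3-fold higher number from compound 1 to compound 3 (0.36 log units; beyond the scatter). Compound 4 `C/C=C/C=C/C(=O)N[C@H](C(=O)NCCCCCCCCCCCCCCCCCC)[C@@H](C)O` has not yet been measured. It differs from compound 3 by prop-1-en-1-yl in place of phenyl on a double-bonded chain carbon bound to a double-bonded chain carbon, the same change that separates compound 1 from compound 2, at the same place. Because that change earlier gave a 1.8-fold higher number from compound 1 to compound 2 (0.26 log units; within the scatter), a step of similar, small size is expected here, a 1.6-fold higher number from compound 3 to compound 4 (0.19 log units; within the scatter). For compound 4 the expected value in this assay is therefore 200000 nM, with a likely range from 90000 nM to 450000 nM, though such a weak number may be reported only as a limit.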

Compound 4, half-maximal inhibitory concentration: 284000 nM
For compound 4 the middle estimate is 1.4-fold (0.15 log units) below the measured one; the measured number falls inside the stated range.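

Replacing phenyl with prop-1-en-1-yl on the core of compound 3 gives a 2.2-fold higher number from compound 3 to compound 4 (0.35 log units; beyond the scatter), and this step agrees with the one seen for the same swap on the core of compound 1: the same change on two cores in this assay, a 1.8-fold higher number (0.26 log units; within the scatter) from compound 1 to compound 2 and a 2.2-fold higher number (0.35 log units; beyond the scatter) from compound 3 to compound 4, 1.2-fold (0.08 log units) apart, within the scatter of two such steps. Adding decyl to the chain with the prop-1-en-1-yl end in place gives a 2.8-fold higher number from compound 2 to compound 4 (0.44 log units; beyond the scatter), and this chain change also carries over from one core to the other: the same change on two cores in this assay, a 2.3-fold higher number (0.36 log units; beyond the scatter) from compound 1 to compound 3 and a 2.8-fold higher number (0.44 log units; beyond the scatter) from compound 2 to compound 4, 1.2-fold (0.08 log units) apart, within the scatter of two such steps. Within these four compounds, each change therefore has much the same size whichever form the other end takes, but this rests on a single set of four compounds in one cell assay and does not show that the same steps would hold on any other core.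

The compounds shown leave open whether an amine or a carboxylic acid in place of phenyl would fit the same pattern. They also leave open how a chain shorter than those here, or one of intermediate length, would behave.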